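From 4-methoxyphenyl to 2-methoxyphenyl in a weak amide series

A few compounds are considered here, and "the series" means these few. Any claim that something is new, unique, unknown or untested is made for them only; others in the source may bear on it.

Compound 1 `COc1ccccc1C(=O)NC(CC(=O)O)c1ccccc1`: > 100000 nM, a limit
Compound 2 `O=C(O)CC(NC(=O)c1cccc(Br)c1)c1ccc(Cl)cc1Cl`: 82500 nM
Compound 3 `COc1ccc(C(=O)NC(CC(=O)O)c2ccc(Cl)cc2Cl)cc1`: > 100000 nM, a limit

In a functional assay on MDA-MB-231 cells (Homo sapiens) for antiproliferative activity, read by MTT assay, with a stated time of 24 h (a higher number here means a weaker inhibitor, a lower number a stronger inhibitor), compound 3 gives > 100000 nM, which is a limit and not a number. Compound 3 thus stands at the limit of > 100000 nM in this assay, at which 2 of the 3 values shown sit. Compound 4 `COc1ccccc1C(=O)NC(CC(=O)O)c1ccc(Cl)cc1Cl` differs from it by 2-methoxyphenyl in place of 4-methoxyphenyl on a carbonyl carbon. Compound 1 also carries 2-methoxyphenyl on its carbonyl carbon. Compound 1 gives > 100000 nM, again a limit. Going by the values given here, the only measured step at this carbonyl carbon is an at least 1.2-fold higher number from compound 2 to compound 3 (0.08 log units; that floor lies within the scatter), so no step beyond the scatter is expected in this assay. The estimated step is an at least 1.0-fold lower number from compound 3 to compound 4 (0.02 log units; that floor lies within the scatter). For compound 4 the estimated value is 95000 nM, with an expected range from 50000 nM to 180000 nM.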

Compound 4, half-maximal inhibitory concentration: > 100000 nM
Compound 4: a limit, no number (the forecaster's own chance of this, stated with the estimate: 60%); middle value at least 1.0-fold (0.02 log units) away from the limit.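

In this assay, moving the methoxy group from 4-methoxyphenyl to 2-methoxyphenyl on the carbonyl carbon still yields no number, only the limit of the assay: the limit of > 100000 nM in this assay, at which 3 of the 4 values shown sit. Going by these compounds alone, the one readable step, an at least 1.2-fold higher number from compound 2 to compound 4 (0.08 log units; that floor lies within the scatter), gives only a floor, so it shows no real difference between 3-bromophenyl and 2-methoxyphenyl here. The other two new steps, with limits at both ends, cannot be read.

On these data alone, it remains open whether an amine or a carboxylic acid on the ring at this carbonyl carbon would give a clearly stronger inhibitor than compound 2.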